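Acetyl to dimethylamino on the pendant phenyl ring

The source may report more compounds than this note shows. Statements on the series, on what has been measured and on what is new or still open speak of the compounds shown alone.

Among the compounds with values here, compound 1 `COc1cc(C)cc(-c2c(-c3ccnc(-c4ccc(C(C)=O)cc4)c3)cnn2CC#N)c1` gives 100% in a functional assay on NCI-H322M cells (Homo sapiens) for cytotoxicity, read by sulforhodamine B assay, with a stated time of 48 h, tested at 100 nM (a higher number here means a weaker effect of the compound at the concentration tested, a lower number a stronger effect), the highest of the three numbers so far. Compound 2 `Cc1cc(O)cc(-c2nn(CC#N)cc2-c2ccnc(-c3ccc(Oc4ccccc4)cc3)c2)c1` gives 95% in this assay, within the scatter of compound 1. Compound 3 `COc1cc(C)cc(-c2nn(CC#N)cc2-c2ccnc(-c3ccc(N(C)C)cc3)c2)c1` gives 49% in this assay, well beyond the scatter below compound 1. The change to compound 4 `COc1cc(C)cc(-c2c(-c3ccnc(-c4ccc(N(C)C)cc4)c3)cnn2CC#N)c1` is dimethylamino in place of acetyl on an aromatic carbon. Within the data shown here, no measured pair with this change exists, so its size is unknown. Compound 3 carries the same dimethylamino group on a core joined in another way and gives 49%, so a step toward a lower number is expected from compound 1 to compound 4, of size a number 38 percentage points lower from compound 1 to compound 4 (beyond the scatter). Compound 4 is estimated at 62%, between 35% and 95%.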

Compound 4, a percentage reported as activity, at one concentration (the size of the read-out at that concentration, not a potency): 20%
Compound 4: middle estimate off by 42 percentage points, on the high side; measured number outside the range, below it.
By their numbers in this assay, from the lowest: compound 4; then compound 3; then compounds 2 and 1 (each within the scatter of the next).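

In this assay, dimethylamino in place of acetyl on the aromatic carbon gives a number 80 percentage points lower from compound 1 to compound 4 (beyond the scatter), so this position, para to a large group, clearly affects the read-out on the core of compound 1. The two groups have the same heavy-atom and hydrogen-bond acceptor counts, so those counts do not separate them. Nothing at hand gives a reason for the step.

Open, going by these compounds, is whether a primary amine, a diethylamino group or a morpholine ring at this position would keep the lower number. Also open, on these data alone, is how a carboxylic acid there would compare with acetyl.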